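This account rests on a few compounds, and the source may have more. Where it says the series, first, only, none or still open, it means among the compounds named here.

For the measured compounds named here, compound 2 `CC(C)NC(=O)/C=C1\CCc2ccc(F)cc21` stands highest of the two numbers measured so far: in a functional assay on the whole organism with Rattus norvegicus as the target, at a dose of 20 mg/kg by the oral route (a lower number here means less inhibition, a higher number more inhibition at the dose given (going by the name of the read-out)), compound 2 gives 71%. Compound 1 `CNC(=O)/C=C1\CCc2ccc(Cl)cc21` differs from compound 2 at two places. In this assay compound 1 gives 25%, a gap beyond the scatter. Compound 3 `CNC(=O)/C=C1\CCc2ccc(F)cc21` carries the change (methyl in place of isopropyl on an amide-type nitrogen). Going by the values given here, no single-change step has been measured here; compound 3 shares the methyl on the amide-type nitrogen with compound 1, which gives 25%, so the step from compound 2 to compound 3 is expected to run downward, beyond the scatter, a number 29 percentage points lower from compound 2 to compound 3 (beyond the scatter). For compound 3 the estimate in this assay is 42%, in the range 15% to 70%.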

Compound 3, a percentage reported as inhibition, in the whole organism at one dose (the size of the read-out at that dose, not a potency): 38%
For compound 3 the middle estimate is 4 percentage points above the measured one, within the range that was stated.
By their numbers in this assay, from the lowest: compound 1; then compound 3; then compound 2.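

Working on the same fluoro core, the amide-type nitrogen now reads as a single change in this assay: methyl in place of isopropyl is a large step down (a number 33 percentage points lower from compound 2 to compound 3 (beyond the scatter)). The aromatic carbon also reads alone with the methyl kept, where fluoro in place of chloro is a modest step up (a number 13 percentage points higher from compound 1 to compound 3 (beyond the scatter)). Nothing on hand gives a reason for either step.

Going by these compounds, whether the isopropyl step holds with chloro on the aromatic carbon stays open. So does how an ethyl or a tert-butyl on the amide-type nitrogen would read.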